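The source may hold more compounds than are shown below. What is called first, only, known or untested is meant among the compounds shown, and "the series" means these compounds.

Measured compounds:
compound 1 `COCc1ccc2nc(-c3ccccn3)c(Nc3cccc(F)c3)n2c1` — 16000 nM
compound 2 `CN(C)Cc1ccc2nc(-c3ccccn3)c(Nc3cccc(F)c3)n2c1` — > 50000 nM
compound 3 `COCc1ccn2c(Nc3cccc(F)c3)c(-c3ccccn3)nc2c1` — 7370 nM

In an ADME assay on THP-1 cells (Homo sapiens) for cytotoxicity (a lower number here means that less compound is tolerated, a higher number that more compound is tolerated), compound 1 gives 16000 nM. Compound 2 gives only a limit of the assay, > 50000 nM. Compound 3 gives 7370 nM in this assay, the lowest of the two numbers given; the nearest is compound 1, as the two values show.

Within the data shown here, the one change made between measured compounds is dimethylamino in place of methoxy on a saturated chain carbon bound to an aromatic carbon, and it produced an at least 3.1-fold higher number from compound 1 to compound 2 (0.49 log units; beyond the scatter). That the step is only a lower bound rests on (the limit of > 50000 nM in this assay, at which 1 of the 3 values shown sits).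

Compound 3 and compound 1 have the same atoms joined differently; the difference between the two cores is not broken down here. Compound 4 `CN(C)Cc1ccn2c(Nc3cccc(F)c3)c(-c3ccccn3)nc2c1` is not yet measured. It differs from compound 3 by dimethylamino in place of methoxy on a saturated chain carbon bound to an aromatic carbon, the same change as from compound 1 to compound 2.

On the basis of an at least 3.1-fold higher number from compound 1 to compound 2 (0.49 log units; beyond the scatter), the author expects a 3.4-fold higher number from compound 3 to compound 4 (0.53 log units; beyond the scatter). Compound 4 is therefore estimated at 25000 nM, likely between 9000 nM and 60000 nM.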

Compound 4, half-maximal cytotoxic concentration: 33300 nM
Estimate against measurement, compound 4: 1.3-fold (0.12 log units) below; the measured number falls inside the stated range.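

In this assay, dimethylamino in place of methoxy on a saturated chain carbon bound to an aromatic carbon gives a 4.5-fold higher number from compound 3 to compound 4 (0.65 log units; beyond the scatter). Compound 2 gives > 50000 nM, which is a limit of the assay and not a number. The change moves the number in the same direction on both cores, which shows that its direction carries over between these two cores, but it does not show that its size carries over, and two cores cannot speak for the whole series: the same change on two cores in this assay, an at least 3.1-fold higher number (0.49 log units; beyond the scatter) from compound 1 to compound 2 and a 4.5-fold higher number (0.65 log units; beyond the scatter) from compound 3 to compound 4; the limit leaves it open whether they differ

The compounds shown leave open whether a primary amine or a carboxylic acid in place of dimethylamino, on the same saturated chain carbon, would move the number in the same direction on either core. They also leave open whether a longer chain carrying the dimethylamino would give a step like those seen here.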